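The compounds below may be only part of what the source reports. "The series", "measured", "known", "first", "only" and "open" are said of these compounds alone.

Measured so far in a functional assay on SK-N-SH cells (Homo sapiens) for cytotoxicity, read by MTT assay, with a stated time of 48 h; on this read-out lower numbers stand for stronger inhibition and higher numbers for weaker inhibition:

compound 1, `O=C1Nc2ccccc2C1(c1c[nH]c2ccc([N+](=O)[O-])cc12)c1c[nH]c2ccc([N+](=O)[O-])cc12`: 990 nM
compound 2, `COC(=O)c1ccc2[nH]cc(C3(c4c[nH]c5ccc(C(=O)OC)cc45)C(=O)Nc4ccc(Cl)cc43)c2c1`: 9900 nM
compound 3, `O=C1Nc2ccc(Cl)cc2C1(c1c[nH]c2ccc(Br)cc12)c1c[nH]c2ccc(Br)cc12`: 1040 nM

Compound 3 stands second highest of the three numbers. Its nearest neighbour is compound 1, whose number is within the scatter of that of compound 3, so the two are not told apart here. Compound 2 stands furthest from compound 3, with a clearly higher number, beyond the scatter, in this assay.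

Compound 4, `O=C1Nc2ccccc2C1(c1c[nH]c2ccc(Br)cc12)c1c[nH]c2ccc(Br)cc12`, is not yet measured. It differs from compound 3 in one place: hydrogen in place of chloro on an aromatic carbon. The substituent on an aromatic carbon of the six-membered aromatic ring of carbon only, part of a fused system of two rings, is removed; the two bromo groups elsewhere are kept.

Going by the values given here, no measured pair differing only in this way is available, so the size of the step is not directly known. Compound 1 carries hydrogen at this position and compound 3 carries chloro, and their numbers in this assay lie within the scatter of each other, though they differ elsewhere as well. The step from compound 3 to compound 4 is therefore expected to be small, a 1.1-fold higher number from compound 3 to compound 4 (0.02 log units; within the scatter), in no direction beyond the scatter. Compound 4 is estimated at 1100 nM, with a range from 400 nM to 3000 nM.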

Compound 4, half-maximal inhibitory concentration: 930 nM
Compound 4: middle estimate off by 1.2-fold (0.07 log units), on the high side; the measured number falls inside the stated range.
By their numbers in this assay, from the lowest: compounds 4, 1 and 3 (each within the scatter of the next); then compound 2.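

In this assay, going by these compounds alone, hydrogen in place of chloro on an aromatic carbon gives a 1.1-fold lower number from compound 3 to compound 4 (0.05 log units; within the scatter), the first direct reading of this position with the two bromo groups kept. The earlier link between chloro and hydrogen here came only from compounds that also differ elsewhere; this single pair now shows that the two substituents are not told apart at this position. Nothing at hand accounts for this result.

Still open, from the compounds shown here alone, is how this aromatic carbon responds to a group other than hydrogen or chloro, such as an amine, a carboxylic acid or a longer alkyl chain. Also open, going by these compounds, is whether the same change gives a similar step when the nitro groups of compound 1 replace the two bromo groups.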